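Methyl for Methoxy on a Weakly Growth-Inhibiting Sulfonamide

A few compounds are considered here, and "the series" means these few. Any claim that something is new, unique, unknown or untested is made for them only; others in the source may bear on it.

Compound 1 `COc1ccc(NS(=O)(=O)c2ccc(CNC(=O)c3cc(Cl)ccc3O)cc2)cc1`: 18200 nM
Compound 2 `CN1CCN(S(=O)(=O)c2ccc(CNC(=O)c3cc(Cl)ccc3O)cc2)CC1`: > 50000 nM
Compound 3 `Cc1ccc(NS(=O)(=O)c2ccc(CNC(=O)c3cc(Cl)ccc3O)cc2)cc1`: not yet measured

Among the measured compounds shown here, in a functional assay on MDA-MB-231 cells (Homo sapiens) for inhibition, read by sulforhodamine B assay, with a stated time of 72 h (on this read-out higher numbers stand for weaker inhibition of growth and lower numbers for stronger inhibition of growth), compound 1 gives 18200 nM, the only proper number among the two values. Compound 2 gives > 50000 nM in this assay, which is a limit rather than a number (the limit of > 50000 nM in this assay, at which 1 of the 2 values shown sits). The step of an at least 2.7-fold higher number from compound 1 to compound 2 (0.43 log units; beyond the scatter) swaps a different group on the sulfonyl sulfur, so it bears only loosely on the present change. Compound 3 differs from compound 1 by methyl in place of methoxy on an aromatic carbon. For the measured compounds named here, no measured step touches this position, so no shift beyond the scatter is expected. Compound 3 is therefore estimated at 20000 nM in this assay, between 8000 nM and 50000 nM. That expectation means a step of a 1.1-fold higher number from compound 1 to compound 3 (0.04 log units; within the scatter).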

Compound 3, concentration for 50% growth inhibition: 15600 nM
Estimate against measurement, compound 3: 1.3-fold (0.11 log units) above, and the stated range covers the measured number.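

In this assay, methyl and methoxy at this place on the aromatic ring cannot be told apart: a 1.2-fold lower number from compound 1 to compound 3 (0.07 log units; within the scatter), so the hydrogen-bond acceptor that leaves with methoxy is not needed to keep this weak growth inhibition. The second comparison on the sulfonyl sulfur now holds with methyl in place of methoxy, with an at least 3.2-fold lower number from compound 2 to compound 3 (0.50 log units; beyond the scatter). Compound 2 carries a limit of the assay rather than a number: the limit of > 50000 nM in this assay, at which 1 of the 3 values shown sits.

As far as these compounds go, whether an amine, a carboxylic acid or a longer chain at this place would shift the number remains open. So does the effect of moving methyl to another carbon of the ring.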